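A Smaller Aryl Group and an Unchanged Cytotoxicity Limit

This account rests on a few compounds, and the source may have more. Where it says the series, first, only, none or still open, it means among the compounds named here.

Of the compounds shown here, three have been measured in an ADME assay on HepG2 2.2.15 cells (Homo sapiens) for cytotoxicity, read by MTT assay, with stated times of 3 days and 7 days; on this read-out higher numbers stand for lower toxicity in this test and lower numbers for higher toxicity in this test. Compound 1 `O=C(NCc1ccc(Cl)cc1)c1cc(-c2ccccc2)nc2ccccc12` gives > 20000 nM, which is a limit of the assay and not a number. Compound 2 `CC(C)Cc1ccc(-c2cc(C(=O)N3CCC(Cc4ccccc4)CC3)c3ccccc3n2)cc1` gives > 20000 nM in this assay, again a limit rather than a number. Compound 3 `CCOc1cccc(-c2cc(C(=O)NCc3nnc(C(C)(C)CC)s3)c3ccccc3n2)c1` gives > 20000 nM in this assay, also a limit. Compound 2 therefore stands where every measured compound stands, at the limit of > 20000 nM in this assay, at which 3 of the 3 values shown sit, and no number separates it from compound 1 or compound 3. For the measured compounds named here, no step between two measured compounds that differ in one place is available, so nothing is known about how a single change moves the read-out.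

Compound 4 `Cc1cccc(-c2cc(C(=O)N3CCC(Cc4ccccc4)CC3)c3ccccc3n2)c1` has not yet been measured in this assay. It differs from compound 2 in one place, (3-methylphenyl in place of 4-isobutylphenyl on an aromatic carbon); the 4-isobutylphenyl of compound 2 is replaced by 3-methylphenyl, a smaller group with fewer carbons, at the same position of the shared core. Since all three measured compounds sit at the limit, the expected step is a step that the limit leaves unreadable from compound 2 to compound 4, none beyond the scatter. Compound 4 is expected to give about 25000 nM in this assay, within a range from 12000 nM to 60000 nM, most likely again reported as a limit.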

Compound 4, half-maximal cytotoxic concentration: > 20000 nM
Compound 4 gave a limit, no number; the forecaster's own chance of this, stated with the estimate: 80%; the middle value is on the limit's open side.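

Compound 2 and compound 4 both give a limit in this assay, so no step between them can be read, and the values shown all stand at the same point: the limit of > 20000 nM in this assay, at which 4 of the 4 values shown sit.

The compounds shown leave open how far any of them lies from that limit, and whether 3-methylphenyl in place of 4-isobutylphenyl changes the read-out at all.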